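Compound 4: loss of 1-hydroxy-1-methylethyl from compound 3

The source may report more compounds than this note shows. Statements on the series, on what has been measured and on what is new or still open speak of the compounds shown alone.

Measured in an ADME assay on microsomes from liver (Homo sapiens) for metabolic stability; a higher number here means that the compound lasts longer, a lower number that the compound disappears faster:
- compound 1 `COc1cc(OCc2cccc(-c3ccc(OC)nc3)c2)c2cc(-c3cn4nc(OC)sc4n3)oc2c1`: 0.733 h
- compound 2 `COc1cc(OCc2cccc(-c3cnc(OC)nc3)c2)c2cc(-c3cn4nc(OC)sc4n3)oc2c1`: 0.6 h
- compound 3 `COc1cc(OCc2csc(-c3ccc(C(C)(C)O)cc3)n2)c2cc(-c3cn4nc(OC)sc4n3)oc2c1`: 1.83 h

Compound 3 holds the highest of the three numbers, and its gap to each of the other two lies beyond the scatter. Compound 4 `COc1cc(OCc2csc(-c3ccccc3)n2)c2cc(-c3cn4nc(OC)sc4n3)oc2c1` is still to be measured in this assay. It differs from compound 3 as follows: hydrogen in place of 1-hydroxy-1-methylethyl on an aromatic carbon. Hydrogen stands in place of 1-hydroxy-1-methylethyl on an aromatic carbon, so 4-(1-hydroxy-1-methylethyl)phenyl becomes phenyl.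

Among the compounds with values here, the only measured step is a 1.2-fold lower number from compound 1 to compound 2 (0.09 log units; within the scatter). It lies within the scatter and involves a different group, so it says little here. Within the data shown here, no measured step removes 1-hydroxy-1-methylethyl. Compound 1 at 0.733 h and compound 2 at 0.6 h also lack this group, but they differ from compound 3 elsewhere too, which makes them weak guides. They still suggest a move downward. The expected step is a 1.8-fold lower number from compound 3 to compound 4 (0.26 log units; within the scatter). For compound 4 the estimated half-life is 1 h, with an expected range of 0.4 h to 2.3 h.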

Compound 4, half-life: 1.33 h
The estimate for compound 4 lay 1.3-fold (0.12 log units) below the measured number; the range from low to high includes it.
By their numbers in this assay, from the lowest: compounds 2, 1, 4 and 3 (each within the scatter of the next, the first and the last beyond it).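

In this assay, within the data shown here, this is the first direct reading at this position, an aromatic carbon of a six-membered aromatic ring of carbon only, para to a large group: hydrogen in place of 1-hydroxy-1-methylethyl gives a 1.4-fold lower number from compound 3 to compound 4 (0.14 log units; within the scatter). The 1-hydroxy-1-methylethyl group can therefore be removed without a step that clears the scatter, so the high number of compound 3 cannot be tied to this group. No measurement shown offers an explanation for this result.

Still open, from the compounds shown here alone, is whether an amine or a carboxylic acid at this position would give a step beyond the scatter. The compounds shown also do not isolate which structural difference separates compound 3 from compound 1 and compound 2, as those pairs differ in more than one place.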